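Inverting Both Ring Stereocentres in a Chloro-Pyridinone Amide Series

The source may report more compounds than this note shows. Statements on the series, on what has been measured and on what is new or still open speak of the compounds shown alone.

Of the compounds shown here, three sharing one core have been measured in an assay on isolated protein for inhibition of Rho-associated protein kinase 2 (Homo sapiens); on this read-out higher numbers stand for weaker inhibition and lower numbers for stronger inhibition. For the measured compounds named here, compound 1 `CC(C)N[C@H](C(=O)Nc1cc2cc[nH]c(=O)c2cc1Cl)C1CCCCC1` gives 25 nM, and compound 2 `N[C@H](C(=O)Nc1cc2cc[nH]c(=O)c2cc1Cl)C1CCCCC1` gives 20 nM; the single step between them, a 1.3-fold lower number from compound 1 to compound 2 (0.10 log units; within the scatter), is too small to read. Compound 3 `N[C@H]1CC[C@H](C(=O)Nc2cc3cc[nH]c(=O)c3cc2Cl)CC1` gives 330 nM and stands highest of the three, a gap beyond the scatter to both compound 1 and compound 2.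

Compound 4 `N[C@H]1CC[C@@H](C(=O)Nc2cc3cc[nH]c(=O)c3cc2Cl)CC1` is the untested partner of compound 3. The change is the two compounds have the same atoms and bonds and differ only in configuration as drawn: 2 of 2 stereo elements differ (all stereocentres are inverted: mirror images); a stereocentre at a saturated ring carbon is drawn r in compound 3 and s in compound 4; a stereocentre at a saturated ring carbon is drawn r in compound 3 and s in compound 4: the two compounds have the same atoms and bonds and differ only in configuration as drawn, with both stereocentres at saturated ring carbons inverted, so that the two are mirror images.

Going by the values given here, no measured step bears directly on this change. The only step shown, from compound 1 to compound 2, concerns a substituent on an amine nitrogen and says nothing about ring configuration. What the numbers do show is that the ring-bound amine of compound 3 sits well above the open-chain amines of compounds 1 and 2, leaving room for the inverted configuration to move either way. On that basis the author expects compound 4 to land at 100 nM, within 20 nM to 500 nM, a step of a 3.3-fold lower number from compound 3 to compound 4 (0.52 log units; beyond the scatter) that is itself only an estimate.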

Compound 4, half-maximal inhibitory concentration: 15 nM
Compound 4: the middle estimate sits 6.7-fold (0.82 log units) above what was measured, and the stated range ends above it.
By their numbers in this assay, from the lowest: compounds 4, 2 and 1 (each within the scatter of the next); then compound 3.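

In this assay a change of configuration alone gives a 22-fold lower number from compound 3 to compound 4 (1.34 log units; beyond the scatter), which makes the arrangement at the saturated ring carbons a strong handle on this read-out. For the compounds shown here, the only earlier step concerned a substituent on an amine nitrogen and stayed within the scatter, so the earlier compounds gave no sign of how much the read-out could move, and none on ring configuration at all. The whole of the new step can be assigned to the configuration at those two ring carbons, because nothing else separates the pair: the fact that compounds 3 and 4 differ only in the configuration as drawn.

The compounds shown do not tell whether the same gap between the two configurations would survive with a methyl group or an acetyl group on the ring amine, or with a longer chain between the ring and the amine. Going by these compounds alone, they also leave open whether a hydroxyl group or a carboxylic acid in place of that amine would keep a number close to the one compound 4 gives, 15 nM, and they offer no account of why configuration counts for so much here.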